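The source may report more compounds than this note shows. Statements on the series, on what has been measured and on what is new or still open speak of the compounds shown alone.

Three compounds share one core. Compound 1 `Cc1cc2nn(-c3ccccc3)c(N)c2c(=O)[nH]1` gives 5% in an assay on isolated protein for inhibition of MAP kinase-activated protein kinase 5 (Homo sapiens), read by mobility shift assay, tested at 30 uM; on this read-out higher numbers stand for more inhibition at the one concentration tested (going by the name of the read-out) and lower numbers for less inhibition; compound 2 `Nc1c2c(=O)[nH]c(-c3ccccc3)cc2nn1-c1ccccc1` gives 22%; compound 3 `Nc1c2c(=O)[nH]c(-c3ccccn3)cc2nn1-c1ccccc1` gives 2%, the lowest of the three numbers, with compound 1 nearest to it and compound 2 furthest. Compound 4 `COc1ccccc1-c1cc2nn(-c3ccccc3)c(N)c2c(=O)[nH]1` carries 2-methoxyphenyl in place of pyridin-2-yl on an aromatic carbon. For the measured compounds named here, two measured steps bear on this change: a number 20 percentage points lower from compound 2 to compound 3 (beyond the scatter) and a number 3 percentage points lower from compound 1 to compound 3 (within the scatter), while a number 17 percentage points higher from compound 1 to compound 2 (beyond the scatter) shows what a ring of carbon only brought in place of methyl. The group entering compound 4 is likewise a ring of carbon only, as in compound 2, which gave 22%. A modest rise is therefore expected, a number 13 percentage points higher from compound 3 to compound 4 (beyond the scatter). Compound 4 is estimated at 15% in this assay, within 0% to 35%.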

Compound 4, a percentage reported as inhibition, at one concentration (the size of the read-out at that concentration, not a potency): 6%
For compound 4 the middle estimate is 9 percentage points above the measured one; the range from low to high includes it.
By their numbers in this assay, from the lowest: compounds 3, 1 and 4 (each within the scatter of the next); then compound 2.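

Methoxy in place of hydrogen on the phenyl ring gives a number 16 percentage points lower from compound 2 to compound 4 (beyond the scatter), so a ring of carbon only at this position does not by itself hold the number seen for compound 2. The 2-methoxyphenyl group also stands no clear distance from pyridin-2-yl or methyl, with a number 4 percentage points higher from compound 3 to compound 4 (within the scatter) and a number 1 percentage points higher from compound 1 to compound 4 (within the scatter), both small enough to leave these three compounds unseparated. No measurement at hand says why methoxy lowers the number.

Open, on these data alone, is whether an amine or a carboxylic acid in place of that methoxy would keep the number of compound 2, and whether a longer chain in place of the methyl of compound 1 would raise it.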